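A few compounds are considered here, and "the series" means these few. Any claim that something is new, unique, unknown or untested is made for them only; others in the source may bear on it.

Three compounds share one core and differ only in the groups attached to it. In a functional assay on NSCLC cells (Homo sapiens) for inhibition (a lower number here means a stronger inhibitor of growth, a higher number a weaker inhibitor of growth), compound 1 `COc1ccc(-c2nc3sc(Cc4ccccc4)nn3c2SC#N)cc1` gives 52500 nM. Compound 2 `Clc1ccc(-c2cn3nc(Cc4ccccc4)sc3n2)cc1` gives 20900 nM in this assay, and compound 3 `O=Cc1c(-c2ccc(Br)cc2)nc2sc(Cc3ccccc3)nn12` gives 30200 nM in this assay. The number for compound 3 sits between the other two, yet its gap to compound 2 and its gap to compound 1 both lie within the usual scatter, so the three read as one group rather than a ranking. Compound 4 `O=Cc1c(-c2ccc([N+](=O)[O-])cc2)nc2sc(Cc3ccccc3)nn12` differs from compound 3 in one place: nitro in place of bromo on an aromatic carbon. For the measured compounds named here, no measured pair shows what this swap does, so no step beyond the scatter is expected in either direction. The expected step is a 1.0-fold lower number from compound 3 to compound 4 (0.00 log units; within the scatter). Compound 4 is therefore estimated at 30000 nM in this assay, with a likely range from 10000 nM to 90000 nM.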

Compound 4, concentration for total growth inhibition: 45700 nM
For compound 4 the middle estimate is 1.5-fold (0.18 log units) below the measured one; measured number inside the range.
By their numbers in this assay, from the lowest: compounds 2, 3, 4 and 1 (each within the scatter of the next, the first and the last beyond it).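

Putting nitro in place of bromo on the aromatic carbon, para to a large group, gives a 1.5-fold higher number from compound 3 to compound 4 (0.18 log units; within the scatter) in this assay. For the compounds shown here, this is the first direct comparison at a single position, and here a group with more heavy atoms and two hydrogen-bond acceptors does not shift growth inhibition beyond the scatter. No available evidence bears on this result.

From the compounds shown here alone, what an amine or a carboxylic acid on this same carbon would do stays open. So does whether any group here can move the number beyond the scatter.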